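A few compounds are considered here, and "the series" means these few. Any claim that something is new, unique, unknown or untested is made for them only; others in the source may bear on it.

Compound 3 `CNc1cc(-c2c(C)nn(-c3nc(-c4ccc(Cl)c(Cl)c4)c(SC(C)C)s3)c2C(=O)O)ccn1` stands highest of the three measured in a functional assay on BJAB cells (Homo sapiens) for antiproliferative activity, with a stated time of 4 days; a lower number here means that less compound is needed, a higher number that more compound is needed for the effect; compound 3 gives 18000 nM. Compound 1 `COc1cc(-c2c(C)nn(-c3nc(-c4ccc(Cl)c(Cl)c4)c(SC(C)C)s3)c2C(=O)O)cc(C(F)(F)F)c1` gives 1380 nM and compound 2 `Cc1nn(-c2nc(-c3ccc(Cl)c(Cl)c3)c(SC(C)C)s2)c(C(=O)O)c1-c1cccc(F)c1` gives 900 nM, with a 1.5-fold lower number from compound 1 to compound 2 (0.19 log units; within the scatter). Against these, a 13-fold higher number from compound 1 to compound 3 (1.12 log units; beyond the scatter) and a 20-fold higher number from compound 2 to compound 3 (1.30 log units; beyond the scatter), so the compound with the ring containing nitrogen sits well apart from the two carbon-only rings. Compound 4 `CC(=O)Nc1ccc(-c2c(C)nn(-c3nc(-c4ccc(Cl)c(Cl)c4)c(SC(C)C)s3)c2C(=O)O)cc1` differs from compound 3 by 4-acetamidophenyl in place of 2-(methylamino)pyridin-4-yl on an aromatic carbon. Among the compounds with values here, both large steps into compound 3 bear on this change, since compound 4 returns to a six-membered aromatic ring of carbon only, while the acetamido group itself has no measured precedent. A large move toward a lower number is therefore expected in this assay, a 7.2-fold lower number from compound 3 to compound 4 (0.86 log units; beyond the scatter). Compound 4 is estimated at 2500 nM, within 800 nM to 8000 nM.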

Compound 4, half-maximal effective concentration: 139000 nM
Estimate against measurement, compound 4: 56-fold (1.75 log units) below; measured number above the stated range.
By their numbers in this assay, from the lowest: compounds 2 and 1 (each within the scatter of the next); then compound 3; then compound 4.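

In this assay a six-membered aromatic ring of carbon only on this aromatic carbon does not by itself keep the number low, with a 7.7-fold higher number from compound 3 to compound 4 (0.89 log units; beyond the scatter) and with a 150-fold higher number from compound 2 to compound 4 (2.19 log units; beyond the scatter) alongside a 100-fold higher number from compound 1 to compound 4 (2.00 log units; beyond the scatter) in the same direction. Compound 4 goes against the earlier split between carbon-only rings and the ring containing nitrogen, since its carbon-only ring stands above compound 3. Nothing measured here accounts for the rise. From the compounds shown here alone, whether the whole acetamido group or only its carbonyl goes with the rise stays open. A primary amine or an unsubstituted phenyl ring on this carbon would separate these readings.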